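The compounds below may be only part of what the source reports. "The series", "measured", "known", "first", "only" and "open" are said of these compounds alone.

In a functional assay on HL-60 cells (Homo sapiens) for antiproliferative activity, read by MTT assay, with a stated time of 72 h (on this read-out higher numbers stand for weaker inhibition and lower numbers for stronger inhibition), compound 1 `NC1=NC2(CCOCC2)N(OCCCOc2cccc(Cl)c2Cl)C(N)=N1` gives 440 nM and compound 2 `NC1=NC2(CCOCC2)N(OCCCOc2ccc(Cl)cc2Cl)C(N)=N1` gives 330 nM, so compound 2 stands level with compound 1 within the scatter. Compound 3 `NC1=NC2(CCOCC2)N(OCCCOc2ccc(Cl)c(Cl)c2)C(N)=N1` is still unmeasured and differs from compound 2 in one place: 3,4-dichlorophenyl in place of 2,4-dichlorophenyl on an oxygen on a saturated carbon. Among the compounds with values here, the only measured step that bears on this is a 1.3-fold lower number from compound 1 to compound 2 (0.12 log units; within the scatter), which likewise exchanges one dichlorophenyl for another and stays within the scatter. No step beyond the scatter is therefore expected in this assay, and the estimated step is a 1.2-fold higher number from compound 2 to compound 3 (0.08 log units; within the scatter). For compound 3 the estimated value is 400 nM, with a range from 150 nM to 1000 nM.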

Compound 3, half-maximal inhibitory concentration: 1240 nM
For compound 3 the middle estimate is 3.1-fold (0.49 log units) below the measured one; measured number above the stated range.
By their numbers in this assay, from the lowest: compounds 2 and 1 (each within the scatter of the next); then compound 3.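

In this assay the arrangement of the two chlorines on this ring does matter: 3,4-dichlorophenyl gives a 3.8-fold higher number from compound 2 to compound 3 (0.57 log units; beyond the scatter) and also a 2.8-fold higher number from compound 1 to compound 3 (0.45 log units; beyond the scatter), whereas the earlier exchange of one dichlorophenyl for another stayed within the scatter. Of the three groups, 3,4-dichlorophenyl is thus the one that separates from the other two. Nothing given here accounts for this difference. Going by these compounds, whether a plain phenyl or a methoxyphenyl would side with compound 3 or with compound 2 remains open, as does the effect of a longer chain.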